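The source may hold more compounds than are shown below. What is called first, only, known or untested is meant among the compounds shown, and "the series" means these compounds.

Measured so far:
compound 1 `COc1ccc(C(=O)c2ccccc2)c(Oc2ccnc(Nc3ccc(C#N)cc3)n2)c1`, giving 760 nM;
compound 2 `Cc1cc(C)cc(C(=O)c2cc(Cl)ccc2Oc2cc(C)nc(Nc3ccc(C#N)cc3)n2)c1`, giving 37100 nM.

In an ADME assay on MT4 cells (Homo sapiens) for cytotoxicity, read by MTT assay, with a stated time of 5 days (a lower number here means that less compound is tolerated, a higher number that more compound is tolerated), compound 1 gives 760 nM, the lowest of the two numbers available. For the measured compounds named here, the only other measured compound, compound 2, gives 37100 nM, a far higher number, well beyond the scatter; but compound 2 differs from compound 1 in several places at once, so the two values show only that the gap is large and say nothing about which part of the structure carries it.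

Compound 3 `COc1ccc(C(=O)c2ccccc2)c(Oc2cc(C)nc(Nc3ccc(C#N)cc3)n2)c1` has not been measured in this assay. It differs from compound 1 by a single change: methyl in place of hydrogen on an aromatic carbon. Going by the values given here, no step between measured compounds that matches this change is available, so the size of the step cannot be read from the data. A single methyl in place of a hydrogen is a small change, and the expectation is a step of modest size, if any, with a slight lean toward a higher number, which would follow the direction of compound 2 without assuming its full size. The step from compound 1 to compound 3 is therefore expected to be a 2.0-fold higher number from compound 1 to compound 3 (0.30 log units; within the scatter). In this assay compound 3 is expected to give about 1500 nM, with a plausible range from 400 nM to 6000 nM.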

Compound 3, half-maximal cytotoxic concentration: 4900 nM
For compound 3 the middle estimate is 3.3-fold (0.51 log units) below the measured one; low and high end bracket the measured number.
By their numbers in this assay, from the lowest: compound 1; then compound 3; then compound 2.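

In this assay, for the compounds shown here, this pair supplies the first step that can be tied to a single change: a 6.4-fold higher number from compound 1 to compound 3 (0.81 log units; beyond the scatter) with methyl in place of hydrogen on an aromatic carbon, next to the ring nitrogen of the six-membered aromatic ring. The earlier values showed only a large gap across several differences at once, whereas this step shows that one methyl at this position is enough on its own to move the number beyond the scatter, toward more compound being tolerated. No measurement on hand accounts for the step, so it stands as an observation on this one pair.

The compounds shown leave open whether an ethyl group, a longer chain or an amine on the same carbon would move the number further, move it the other way or leave it in place. From the compounds shown here alone, compound 2 also carries this methyl alongside its other differences, so how much of the value of compound 2, 37100 nM, goes with the methyl remains open as well.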